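Piperidin-2-yl in Place of Imidazolyl: Expected Solubility

The source may report more compounds than this note shows. Statements on the series, on what has been measured and on what is new or still open speak of the compounds shown alone.

Compound 1 `Cc1cc(NCc2ccncc2)n2nc(C)c(-c3ccccc3)c2n1`: 134000 nM
Compound 2 `Cc1cc(NCc2nccn2C)n2nc(C)c(-c3ccccc3)c2n1`: 26900 nM
Compound 3 `Cc1cc(NCc2ccccn2)n2ncc(-c3ccc(C(=O)Nc4ccccc4)cc3)c2n1`: 5000 nM

In a physicochemical assay for solubility, read by HPLC, using the shake flask method, measured as kinetic solubility, with a stated time of 2 h, at pH 7.4 (on this read-out higher numbers stand for higher solubility and lower numbers for lower solubility), compound 2 stands second highest of the three measured compounds, with compound 1 at 134000 nM above it and compound 3 at 5000 nM below it. Compound 4 `Cc1cc(NCC2CCCCN2)n2nc(C)c(-c3ccccc3)c2n1` differs from compound 2 by piperidin-2-yl in place of 1-methyl-1H-imidazol-2-yl on a saturated chain carbon bound to a nitrogen on an aromatic ring. Going by the values given here, the only single-point step measured, a 5.0-fold lower number from compound 1 to compound 2 (0.70 log units; beyond the scatter), exchanges one aromatic ring for another at that same place and so does not cover a change to a saturated ring; compound 3 differs from compound 2 in more than one place and gives no step. The direction therefore rests on the structural change alone. Compound 4 is expected to give 80000 nM, estimated between 20000 nM and 300000 nM. The expected step is a 3.0-fold higher number from compound 2 to compound 4 (0.47 log units; beyond the scatter), an estimated rise with wide uncertainty.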

Compound 4, solubility: 189000 nM
Estimate against measurement, compound 4: 2.4-fold (0.37 log units) below; low and high end bracket the measured number.
By their numbers in this assay, from the lowest: compound 3; then compound 2; then compounds 1 and 4 (each within the scatter of the next).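

In this assay, going by these compounds alone, a saturated ring now stands on a saturated chain carbon bound to a nitrogen on an aromatic ring, where the earlier compounds carried only aromatic rings. Piperidin-2-yl in place of 1-methyl-1H-imidazol-2-yl gives a 7.0-fold higher number from compound 2 to compound 4 (0.85 log units; beyond the scatter), while piperidin-2-yl in place of pyridin-4-yl gives a 1.4-fold higher number from compound 1 to compound 4 (0.15 log units; within the scatter), so an aromatic ring is not required here for a number of this size. Nothing measured here explains these differences.

On these data alone, how piperidin-4-yl, a morpholin-2-yl ring or an open-chain amine would read at this place remains open, as does whether the step to piperidin-2-yl carries over to the core of compound 3.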